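Ethoxy in Place of Ethyl: Expected Partial Recovery

The compounds below may be only part of what the source reports. "The series", "measured", "known", "first", "only" and "open" are said of these compounds alone.

Measured compounds:
compound 1, `COc1ccc(S(=O)(=O)NC(=O)Nc2ccc(Cl)cc2)s1`: 93%
compound 2, `CCc1ccc(S(=O)(=O)NC(=O)Nc2ccc(Cl)cc2)s1`: 57%

Compound 2 is the lower of the two numbers in a functional assay on the whole organism (6C3HED cells, Mus musculus) for inhibition, at a dose of 150 mg/kg by the oral route; a higher number here means more inhibition at the dose given (going by the name of the read-out), a lower number less inhibition; compound 1 stands well above it. Compound 3, `CCOc1ccc(S(=O)(=O)NC(=O)Nc2ccc(Cl)cc2)s1`, is not yet measured. The change is ethoxy in place of ethyl on an aromatic carbon. Among the measured compounds shown here, only one measured step bears on it: a number 36 percentage points lower from compound 1 to compound 2 (beyond the scatter), a large fall. The change to compound 3 runs the other way in part, since ethoxy shares its oxygen with methoxy and its two-carbon chain with ethyl, so compound 3 is expected to show a number 21 percentage points higher from compound 2 to compound 3 (beyond the scatter). The estimate for compound 3 is 78%, with a range from 55% to 96%.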

Compound 3, a percentage reported as inhibition, in the whole organism at one dose (the size of the read-out at that dose, not a potency): 69%
For compound 3 the middle estimate is 9 percentage points above the measured one; low and high end bracket the measured number.
By their numbers in this assay, from the lowest: compound 2; then compound 3; then compound 1.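

In this assay, ethoxy in place of ethyl gives a number 12 percentage points higher from compound 2 to compound 3 (beyond the scatter), so the oxygen recovers only part of the fall seen between methoxy and ethyl at this carbon next to the ring sulfur. Methyl in place of hydrogen on the saturated chain carbon bound to the oxygen gives a number 24 percentage points lower from compound 1 to compound 3 (beyond the scatter), so the oxygen alone does not restore the methoxy level. Nothing available explains either step. Going by these compounds, what a propoxy chain or an amine at this carbon would give remains open, as does whether this order holds at other doses.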